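The source may hold more compounds than are shown below. What is called first, only, known or untested is meant among the compounds shown, and "the series" means these compounds.

Compound 1 `O=c1cc(NC2CCCCC2)cc(/C=C/c2ccccc2)o1`: 2.02 uM
Compound 2 `O=c1cc(NC2CC2)cc(-c2ccccc2)o1`: > 30 uM
Compound 3 `COc1ccc(Nc2cc(C)oc(=O)c2)cc1`: > 30 uM

In a functional assay on KB cells (Homo sapiens) for cytotoxicity, read by MTT assay, with a stated time of 72 h (a higher number here means that more compound is needed for the effect, a lower number that less compound is needed), compound 1 gives 2.02 uM. For compound 2 this assay reports only a limit, > 30 uM. For compound 3 it likewise reports only a limit, > 30 uM, so compound 3 stands at the limit of > 30 uM in this assay, at which 2 of the 3 values shown sit, rather than at a number. Compound 4 `COc1ccc(Nc2cc(C3CCCCC3)oc(=O)c2)cc1` differs from compound 3 by cyclohexyl in place of methyl on an aromatic carbon. Within the data shown here, no measured pair shows this change by itself. Compound 1 carries larger groups on the shared core and gives 2.02 uM. On that basis a gain is expected, estimated as an at least 2.0-fold lower number from compound 3 to compound 4 (0.30 log units; that floor lies within the scatter), though compound 3 starts at a limit and the true step may be smaller. Compound 4 is expected to give 15 uM, between 3 uM and 40 uM.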

Compound 4, concentration for half-maximal effect: 8.32 uM
Compound 4: the middle estimate sits 1.8-fold (0.26 log units) above what was measured; measured number inside the range.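

In this assay compound 3 is reported only as a limit, > 30 uM. Cyclohexyl in place of methyl, on an aromatic carbon next to the ring oxygen, gives an at least 3.6-fold lower number from compound 3 to compound 4 (0.55 log units; beyond the scatter), the first step here between compounds that differ in one place, and it shows that this position tolerates the larger ring with a gain in cytotoxicity. The full size of the step stays unknown because its starting point is a limit: the limit of > 30 uM in this assay, at which 2 of the 4 values shown sit.

Still open, from the compounds shown here alone, is whether a ring is needed at this position, or whether a hexyl chain or an amine would serve as well as cyclohexyl.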